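Swapping the benzyl ether tail: from nitrile to fluorine

A few compounds are considered here, and "the series" means these few. Any claim that something is new, unique, unknown or untested is made for them only; others in the source may bear on it.

Measured compounds in a functional assay on Mahlavu cells (Homo sapiens) for antiproliferative activity, read by sulforhodamine B assay, with a stated time of 72 h; on this read-out lower numbers stand for stronger inhibition and higher numbers for weaker inhibition:
- compound 1 `Cc1ccc(COc2ccc(-c3cc(CN4CCN(Cc5ccc(C(F)(F)F)cc5)CC4)no3)cc2)cc1` gives 7500 nM
- compound 2 `Cc1cc(C)cc(COc2ccc(-c3cc(CN4CCN(Cc5ccc(C(F)(F)F)cc5)CC4)no3)cc2)c1` gives 6000 nM
- compound 3 `N#Cc1ccccc1COc1ccc(-c2cc(CN3CCN(Cc4ccc(C(F)(F)F)cc4)CC3)no2)cc1` gives 3500 nM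

Compound 3 holds the lowest of the three numbers shown, but its margin is small: the step of a 1.7-fold lower number from compound 2 to compound 3 (0.23 log units; within the scatter) stays within the scatter, and only the step of a 2.1-fold lower number from compound 1 to compound 3 (0.33 log units; beyond the scatter) reaches beyond it. Compounds 1 and 2 sit close together, as the step of a 1.3-fold lower number from compound 1 to compound 2 (0.10 log units; within the scatter) shows. All three share the same core and differ only in the aryl ring hanging from the saturated chain carbon bound to an oxygen on an aromatic ring.

Compound 4 `Fc1ccc(COc2ccc(-c3cc(CN4CCN(Cc5ccc(C(F)(F)F)cc5)CC4)no3)cc2)cc1` continues this series. Relative to compound 3 the change is 4-fluorophenyl in place of 2-cyanophenyl on a saturated chain carbon bound to an oxygen on an aromatic ring. The measured steps that bear on it are those that replace one aryl group by another at the same place, and each of them was modest in size, as the steps of a 1.3-fold lower number from compound 1 to compound 2 (0.10 log units; within the scatter), a 2.1-fold lower number from compound 1 to compound 3 (0.33 log units; beyond the scatter) and a 1.7-fold lower number from compound 2 to compound 3 (0.23 log units; within the scatter) show. Compound 4 carries a single small substituent on its ring, which resembles compound 1 more than compound 3, so the expectation is a somewhat higher number than compound 3, though hardly beyond the scatter. The expected step is a 1.6-fold higher number from compound 3 to compound 4 (0.20 log units; within the scatter). Compound 4 is therefore estimated at 5500 nM in this assay, with a plausible range from 2500 nM to 12000 nM.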

Compound 4, half-maximal inhibitory concentration: 3100 nM
Estimate against measurement, compound 4: 1.8-fold (0.25 log units) above, and the stated range covers the measured number.
By their numbers in this assay, from the lowest: compounds 4, 3, 2 and 1 (each within the scatter of the next, the first and the last beyond it).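

In this assay, the step of a 1.1-fold lower number from compound 3 to compound 4 (0.05 log units; within the scatter) stays within the scatter, so a 4-fluorophenyl ring serves as well as a 2-cyanophenyl ring at this position, and the nitrile is not needed to reach this level of inhibition. Among the compounds shown here, the step of a 1.9-fold lower number from compound 2 to compound 4 (0.29 log units; within the scatter) also stays within the scatter, while a 2.4-fold lower number from compound 1 to compound 4 (0.38 log units; beyond the scatter) goes beyond it; that last pair differs only by fluoro in place of methyl on an aromatic carbon, so even this small exchange produces a modest but readable change, something the earlier compounds, whose rings differ more widely, could not show. Nothing measured here explains why these two groups differ in this way.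

From compound 3 to compound 4, both the group and its place on the ring change together, so the effect of each cannot be separated. Going by these compounds, it also remains open whether a ring carrying an amine or a carboxylic acid, or a longer chain in place of the saturated chain carbon bound to the oxygen, would move the number further than any of these aryl swaps.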